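The compounds below may be only part of what the source reports. "The series", "measured", "known", "first", "only" and "open" are said of these compounds alone.

Compound 1 `CSc1nc(=O)ccn1[C@@H]1O[C@H](COP(=O)(O)OP(=O)(O)O)[C@@H](O)[C@H]1O` gives 523 nM in an in vitro functional assay on 1321-N1 cells for agonist activity at P2Y purinoceptor 2 (Homo sapiens), read by scintillation proximity assay and inositol phosphate accumulation; a lower number here means that less compound is needed, a higher number that more compound is needed for the effect.
Compound 2 `CCCSc1nc(=O)ccn1[C@@H]1O[C@H](COP(=O)(O)OP(=O)(O)O)[C@@H](O)[C@H]1O` gives 1200 nM in this assay.

In this assay compound 2 stands at the higher of the two numbers, with a 2.3-fold higher number from compound 1 to compound 2 (0.36 log units; beyond the scatter). Compound 3 `COc1nc(=O)ccn1[C@@H]1O[C@H](COP(=O)(O)OP(=O)(O)O)[C@@H](O)[C@H]1O` differs from compound 2 by methoxy in place of propylsulfanyl on an aromatic carbon. Within the data shown here, the one measured step that bears on this change is a 2.3-fold higher number from compound 1 to compound 2 (0.36 log units; beyond the scatter), in which the added ethyl raised the number by a modest amount. Among the measured compounds shown here, compound 3 removes that chain and also exchanges the sulfur for oxygen, and no measured step covers that exchange. Compound 3 is therefore expected to move back toward the number of compound 1. For compound 3 the expected step is a 2.0-fold lower number from compound 2 to compound 3 (0.30 log units; within the scatter), an estimate of 600 nM with a range from 200 nM to 2000 nM.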

Compound 3, half-maximal effective concentration: 907 nM
Estimate against measurement, compound 3: 1.5-fold (0.18 log units) below, and the stated range covers the measured number.
By their numbers in this assay, from the lowest: compounds 1, 3 and 2 (each within the scatter of the next, the first and the last beyond it).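

On this aromatic carbon between two ring nitrogen atoms, methoxy in place of propylsulfanyl gives a 1.3-fold lower number from compound 2 to compound 3 (0.12 log units; within the scatter) in this assay, and methoxy in place of methylsulfanyl gives a 1.7-fold higher number from compound 1 to compound 3 (0.24 log units; within the scatter). Among these compounds, the oxygen-linked group therefore cannot be told apart from either sulfur-linked group, and the exchange of sulfur for oxygen, which no earlier step covered, stays within the scatter in its direct comparison with methylsulfanyl. Nothing available accounts for this result.

As far as these compounds go, whether a longer chain on the oxygen would separate from methoxy remains open. So does how an amine at this carbon would compare.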